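Trifluoromethyl to Hydrogen: Expected Effect on Cell Growth Inhibition

A few compounds are considered here, and "the series" means these few. Any claim that something is new, unique, unknown or untested is made for them only; others in the source may bear on it.

Measured so far in a functional assay on HepG2 cells (Homo sapiens) for cytotoxicity, read by MTT assay, with a stated time of 72 h; on this read-out lower numbers stand for stronger inhibition and higher numbers for weaker inhibition:
- compound 1, `COc1ccc2ccc(=O)oc2c1C(/C=C/c1ccc(C(F)(F)F)cc1)=N/NC(N)=O`: compound 1 gives 96 nM
- compound 2, `COc1ccc2ccc(=O)oc2c1C1=NN(C(C)=O)C(c2ccccc2)C1`: compound 2 gives 52 nM

On the two numbers available, compound 1 holds the higher one, but its gap to compound 2 lies within the usual scatter of repeated measurements, so the two compounds cannot be told apart in this assay. Among the compounds with values here, no step between compounds differing in a single place has been measured, so nothing is known yet about how a change at the aryl end of the chain shifts the read-out.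

Compound 3, `COc1ccc2ccc(=O)oc2c1C(/C=C/c1ccccc1)=N/NC(N)=O`, is the next compound to be measured. It differs from compound 1 by hydrogen in place of trifluoromethyl on an aromatic carbon. Within the data shown here, since no comparable step exists among the measured compounds, the expectation rests on the size of the group lost: a modest move toward a higher number is expected, a 1.7-fold higher number from compound 1 to compound 3 (0.22 log units; within the scatter), though a result within the scatter of compound 1 would not surprise. Compound 3 is therefore estimated at 160 nM in this assay, with a range from 50 nM to 500 nM.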

Compound 3, half-maximal inhibitory concentration: 82 nM
Beside the measured number, compound 3's estimate is 2.0-fold (0.29 log units) above it; measured number inside the range.
By their numbers in this assay, from the lowest: compounds 2, 3 and 1 (each within the scatter of the next).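

In this assay, within the data shown here, the step of a 1.2-fold lower number from compound 1 to compound 3 (0.07 log units; within the scatter) is the first comparison of compounds that differ in one place, and it lies within the usual scatter. At this position, on an aromatic carbon of the six-membered ring and para to a large group, the change from 4-(trifluoromethyl)phenyl to phenyl therefore gives two compounds that cannot be told apart, so the four heavy atoms of the trifluoromethyl group are not needed to keep a value in this range. Nothing available here accounts for this result.

From the compounds shown here alone, it remains open whether this insensitivity extends to other groups at the same place, such as an amine, a carboxylic acid or a methoxy group. A single step also cannot show whether the same change would behave alike on the phenyl ring of compound 2.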